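From Hydroxyethyl to Dimethylpyrazolyl on the Amino Nitrogen

The source may report more compounds than this note shows. Statements on the series, on what has been measured and on what is new or still open speak of the compounds shown alone.

Among the compounds with values here, in an ADME assay on U-937 cells (Homo sapiens) for inhibition, read by CellTiter-Glo, with a stated time of 72 h (a higher number here means a weaker inhibitor of growth, a lower number a stronger inhibitor of growth), compound 2 `Cc1ccc(NC(=O)c2cccc(C(F)(F)F)c2)cc1N1Cc2cnc(NCCO)nc2N(C)C1=O` gives 8530 nM, the higher of the two numbers measured so far and therefore the weaker growth inhibitor of the pair. Within the data shown here, the only measured comparison is compound 1 `Cc1ccc(NC(=O)c2cccc(C(F)(F)F)c2)cc1N1Cc2cnc(Nc3cnn(C)c3)nc2N(C)C1=O`, which gives 1130 nM. These two differ in one place, with 2-hydroxyethyl in place of 1-methyl-1H-pyrazol-4-yl on a nitrogen on an aromatic ring, and the measured step is a 7.5-fold higher number from compound 1 to compound 2 (0.88 log units; beyond the scatter).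

Compound 3 `Cc1cc(Nc2ncc3c(n2)N(C)C(=O)N(c2cc(NC(=O)c4cccc(C(F)(F)F)c4)ccc2C)C3)n(C)n1` has 1,3-dimethyl-1H-pyrazol-5-yl in place of 2-hydroxyethyl at that same nitrogen: 1,3-dimethyl-1H-pyrazol-5-yl in place of 2-hydroxyethyl on a nitrogen on an aromatic ring. Among the measured compounds shown here, only one measured step bears on this change. Read in reverse, the step to compound 2 from compound 1, a 7.5-fold higher number from compound 1 to compound 2 (0.88 log units; beyond the scatter), suggests a lower number for compound 3. For the measured compounds named here, the entering group is not the one carried by compound 1, however, and no measured pair tests that difference, so only part of that distance is expected to be recovered. The expected change is a 4.3-fold lower number from compound 2 to compound 3 (0.63 log units; beyond the scatter). For compound 3, the estimated value is 2000 nM, with an expected range of 600 nM to 6500 nM.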

Compound 3, concentration for 50% growth inhibition: 2460 nM
Beside the measured number, compound 3's estimate is 1.2-fold (0.09 log units) below it, and the stated range covers the measured number.
By their numbers in this assay, from the lowest: compound 1; then compound 3; then compound 2.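

In this assay, the step of a 3.5-fold lower number from compound 2 to compound 3 (0.54 log units; beyond the scatter) shows that the lower number at this nitrogen is not confined to the 1-methyl-1H-pyrazol-4-yl group of compound 1: a second pyrazole, 1,3-dimethyl-1H-pyrazol-5-yl, also gives a lower number than 2-hydroxyethyl, and neither of the pyrazole-bearing compounds goes against this among the three shown. The two pyrazole groups are nevertheless not interchangeable, since the step of a 2.2-fold higher number from compound 1 to compound 3 (0.34 log units; beyond the scatter) lies beyond the scatter and places compound 3 between the other two compounds. Nothing available explains either step.

The two pyrazole groups differ both in their methyl substitution and in the ring position that carries the nitrogen, so the compounds shown cannot say which of these differences accounts for the step between them. Also open, as far as these compounds go, is whether the lower number requires a pyrazole at all, or whether a plain phenyl ring or a basic chain such as 2-aminoethyl on this nitrogen would place a compound nearer to compound 1 or to compound 2.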